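Fluoropropyl for isopropyl on the oxadiazole of compound 3

The compounds below may be only part of what the source reports. "The series", "measured", "known", "first", "only" and "open" are said of these compounds alone.

Compound 1 `CS(=O)(=O)c1cnc(O[C@H]2CC[C@H](OC3CCN(C(=O)C4(C(F)(F)F)CC4)CC3)CC2)cn1` gives 107 nM in a functional assay on isolated protein for agonist activity at Glucose-dependent insulinotropic receptor (Homo sapiens), read by HTRF and cAMP accumulation; on this read-out higher numbers stand for an effect only at larger amounts of compound and lower numbers for an effect already at smaller amounts.
Compound 2 `CS(=O)(=O)c1cnc(O[C@H]2CC[C@H](OC3CCN(CC4(C(F)(F)F)CC4)CC3)CC2)cn1` gives 62.6 nM in this assay.
Compound 3 `CC(C)c1noc(CN2CCC(O[C@H]3CC[C@H](Oc4cnc(S(C)(=O)=O)cn4)CC3)CC2)n1` gives 14 nM in this assay.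

Among these three, compound 3 stands at the lowest number, and both steps toward it lie beyond the scatter: a 7.6-fold lower number from compound 1 to compound 3 (0.88 log units; beyond the scatter) and a 4.5-fold lower number from compound 2 to compound 3 (0.65 log units; beyond the scatter). The step of a 1.7-fold lower number from compound 1 to compound 2 (0.23 log units; within the scatter) between the two weaker compounds, by contrast, stays within the scatter. Both larger steps replace a trifluoromethylcyclopropyl group with an oxadiazolylmethyl group on the ring nitrogen, and that is where compound 4 `CC(F)Cc1nc(CN2CCC(O[C@H]3CC[C@H](Oc4cnc(S(C)(=O)=O)cn4)CC3)CC2)no1` continues. Its change from compound 3 is 5-(2-fluoropropyl)-1,2,4-oxadiazol-3-yl in place of 3-isopropyl-1,2,4-oxadiazol-5-yl on a saturated chain carbon bound to an amine nitrogen in a ring. The oxadiazole that carried the gain in compound 3 is kept; what changes is the substituent on it and the way the ring is named and joined. For the measured compounds named here, none of the measured steps alters an oxadiazole substituent, so no step bears directly on this change; the measured steps only show that an oxadiazolylmethyl group on this nitrogen is favourable. Compound 4 is therefore expected to stay close to compound 3, with a step of a 1.4-fold higher number from compound 3 to compound 4 (0.15 log units; within the scatter) that may well fall within the scatter. The estimate for compound 4 in this assay is 20 nM, within a range from 6 nM to 70 nM.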

Compound 4, half-maximal effective concentration: 30.3 nM
For compound 4 the middle estimate is 1.5-fold (0.18 log units) below the measured one; the range from low to high includes it.
By their numbers in this assay, from the lowest: compound 3; then compound 4; then compounds 2 and 1 (each within the scatter of the next).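

In this assay, for the compounds shown here, this is the first step that changes the oxadiazolylmethyl group itself, and a 2.2-fold higher number from compound 3 to compound 4 (0.34 log units; beyond the scatter) shows that keeping an oxadiazole on this ring nitrogen does not by itself preserve the number of compound 3. The advantage over the two non-oxadiazole groups remains, though smaller than with compound 3, as shown by a 2.1-fold lower number from compound 2 to compound 4 (0.32 log units; beyond the scatter) and by a 3.5-fold lower number from compound 1 to compound 4 (0.55 log units; beyond the scatter). The new group differs in two ways at once, with a 2-fluoropropyl group in place of isopropyl and the ring joined as a 3-yl rather than a 5-yl, and no supporting measurement explains the higher number.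

The compounds shown cannot separate the contribution of the fluorine from that of the changed ring attachment, so the two effects remain entangled. On these data alone, it also stays open how this assay would read an oxadiazole carrying a plain propyl chain, a longer chain or an amine in the same place.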